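A few compounds are considered here, and "the series" means these few. Any claim that something is new, unique, unknown or untested is made for them only; others in the source may bear on it.

Measured compounds:
compound 1 `O[C@H]1CCCC[C@@H]1N1CCN(CCCc2ccc(Br)cc2)CC1` — in an assay on membranes from cerebrum (strain Sprague-Dawley) for displacement of a labelled ligand from Sigma non-opioid intracellular receptor 1 (Rattus norvegicus), read by scintillation counting, with a stated time of 90 min (a lower number here means a stronger inhibitor, a higher number a weaker inhibitor), compound 1 gives 4.4 nM
compound 2 `O[C@H]1CCC[C@@H]1N1CCN(CCCc2ccccc2Br)CC1` — in this assay compound 2 gives 37.1 nM
compound 3 `O[C@H]1CCC[C@@H]1N1CCN(CCCc2cccc(Br)c2)CC1` — in this assay compound 3 gives 4.8 nM

Compound 3 stands second highest of the three numbers; compound 1 sits within the scatter of it, while compound 2 is the outlier at the high end, separated from compound 3 by a 7.7-fold lower number from compound 2 to compound 3 (0.89 log units; beyond the scatter).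

Compound 4 `O[C@H]1CCC[C@@H]1N1CCN(CCCc2ccc(Br)cc2)CC1` is not yet measured. It differs from compound 3 in one place: 4-bromophenyl in place of 3-bromophenyl on a saturated chain carbon, three bonds along the chain from an amine nitrogen in a ring. Among the compounds with values here, the only measured step at the same place is the move of bromine from the 2-position to the 3-position, a 7.7-fold lower number from compound 2 to compound 3 (0.89 log units; beyond the scatter), a modest step beyond the scatter. Within the data shown here, compound 1 carries a 4-bromophenyl on a different core, so no single step links it to compound 3; its value and that of compound 3 simply lie within the scatter of each other. Among the measured compounds shown here, the change from 3-bromophenyl to 4-bromophenyl is therefore expected to give a step of about a 1.1-fold lower number from compound 3 to compound 4 (0.03 log units; within the scatter) in this assay, that is, no change beyond the scatter, with compound 1 the only guide to the 4-bromophenyl. For compound 4 the expected value in this assay is 4.5 nM, with a range from 2 nM to 10 nM.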

Compound 4, inhibition constant: 8.1 nM
The estimate for compound 4 lay 1.8-fold (0.26 log units) below the measured number; measured number inside the range.
By their numbers in this assay, from the lowest: compounds 1, 3 and 4 (each within the scatter of the next); then compound 2.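

In this assay, 4-bromophenyl in place of 3-bromophenyl gives a 1.7-fold higher number from compound 3 to compound 4 (0.23 log units; within the scatter), so on the shared core these two placements of bromine cannot be told apart. The 2-bromophenyl of compound 2 stands apart from both, as a 4.6-fold lower number from compound 2 to compound 4 (0.66 log units; beyond the scatter) adds to the earlier step of a 7.7-fold lower number from compound 2 to compound 3 (0.89 log units; beyond the scatter), and this separation is the only effect of bromine placement that the series resolves so far. Within the data shown here, the comparison of compound 1 with compound 4 also gives the first reading at the amine nitrogen in a ring: with the 4-bromophenyl held constant, 2-hydroxycyclopentyl in place of 2-hydroxycyclohexyl gives a 1.8-fold higher number from compound 1 to compound 4 (0.27 log units; within the scatter), so this change in the ring size of the hydroxylated group does not register beyond the scatter.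

Nothing available here accounts for the separate standing of the 2-bromophenyl. From the compounds shown here alone, it remains open whether the pattern holds for 2-bromophenyl and 3-bromophenyl on the core of compound 1, and whether it extends to other aryl groups such as 4-chlorophenyl or 4-methoxyphenyl, or to a longer chain.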